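A few compounds are considered here, and "the series" means these few. Any claim that something is new, unique, unknown or untested is made for them only; others in the source may bear on it.

Compound 1 `O=C(Nc1cccc(-n2cc(-c3ccncc3)c(-c3cc(O)cc(Cl)c3)n2)c1)Nc1ccc(Cl)c(C(F)(F)F)c1` carries a hydroxy on the aryl group at the shared core and, in a functional assay on OVCAR-3 cells (Homo sapiens) for inhibition, read by sulforhodamine B assay, with a stated time of 48 h, tested at 1 uM (a higher number here means a weaker effect of the compound at the concentration tested, a lower number a stronger effect), compound 1 gives 91%. Compound 2 `O=C(Nc1cccc(-n2cc(-c3ccncc3)c(-c3cc(O)cc(Cl)c3)n2)c1)Nc1ccc(Cl)c(Cl)c1` is its chloro analogue, and in this assay compound 2 gives 85%. Of the two numbers recorded, compound 1 stands highest, with compound 2 nearest; the step of a number 6 percentage points lower from compound 1 to compound 2 (within the scatter). Compound 3 `COc1cc(Cl)cc(-c2nn(-c3cccc(NC(=O)Nc4ccc(Cl)c(C(F)(F)F)c4)c3)cc2-c2ccncc2)c1` is the next member, not yet measured. The change from compound 1 to compound 3 is methyl in place of hydrogen on an oxygen on an aromatic ring. Going by the values given here, no measured step touches this oxygen: the one step recorded concerns chloro in place of trifluoromethyl and lies within the scatter, so it gives no guide to the hydroxy-to-methoxy change. Both measured numbers are high, and the expected step of a number 3 percentage points lower from compound 1 to compound 3 (within the scatter) is therefore small. Compound 3 is estimated at 88%, within 72% to 100%.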

Compound 3, a percentage reported as activity, at one concentration (the size of the read-out at that concentration, not a potency): 24%
Compound 3: the middle estimate sits 64 percentage points above what was measured; measured number outside the range, below it.
By their numbers in this assay, from the lowest: compound 3; then compounds 2 and 1 (each within the scatter of the next).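

In this assay, the oxygen on the aromatic ring proves a sensitive place: hydroxy to methoxy, with 3-chloro-5-hydroxyphenyl becoming 3-chloro-5-methoxyphenyl, gives a number 67 percentage points lower from compound 1 to compound 3 (beyond the scatter). A lower number here means a stronger effect at the concentration tested. Compound 3 has the stronger effect of this pair. The earlier change, chloro in place of trifluoromethyl, gave only a number 6 percentage points lower from compound 1 to compound 2 (within the scatter), so this is the first step in the series to go beyond the scatter, and no measurement shown accounts for its size.

Open, going by these compounds, is whether the step depends on the methyl itself or on the loss of the hydroxy hydrogen; an ethoxy group, a fluoro or an amine at this place would help separate the two. Also open, on these data alone, is whether the same step holds on the chloro analogue, compound 2.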